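Methoxy for fluoro: the step from compound 3 to compound 4

The source may report more compounds than this note shows. Statements on the series, on what has been measured and on what is new or still open speak of the compounds shown alone.

Measured in an ADME assay on Caco-2 cells (Homo sapiens) for permeability, with a stated time of 2 h; a higher number here means that the compound crosses the layer faster, a lower number that the compound crosses the layer more slowly
- compound 1 `COc1cc2c(cc1OC)CN(Cc1coc(-c3ccc4cc(F)ccc4c3)n1)CC2` gives 0.82 nm/s
- compound 2 `COc1ccc2cc(-c3nc(CN4CCc5cc(OC)c(OC)cc5C4)co3)ccc2c1` gives 3.8 nm/s
- compound 3 `COc1cc2c(cc1OC)CN(Cc1csc(-c3ccc4cc(F)ccc4c3)n1)CC2` gives 9.5 nm/s

Compound 3 stands highest of the three, and its gaps to compound 1 and compound 2 both lie beyond the scatter. Compound 4 `COc1ccc2cc(-c3nc(CN4CCc5cc(OC)c(OC)cc5C4)cs3)ccc2c1` remains unmeasured and differs from compound 3 by methoxy in place of fluoro on an aromatic carbon on the same aromatic carbon position type. Within the data shown here, one measured step bears on this change, the same replacement on a core that differs from that of compound 3. That step is a 4.6-fold higher number from compound 1 to compound 2 (0.67 log units; beyond the scatter) and counts as modest. A single precedent gives limited support, so a rise in this assay of similar or somewhat smaller size is expected. The estimated step is a 2.9-fold higher number from compound 3 to compound 4 (0.47 log units; beyond the scatter) in this series. For compound 4 the estimate is 28 nm/s with an expected range from 10 nm/s to 75 nm/s for now.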

Compound 4, apparent permeability: 6 nm/s
For compound 4 the middle estimate is 4.7-fold (0.67 log units) above the measured one, and the stated range ends above it.
By their numbers in this assay, from the lowest: compound 1; then compounds 2, 4 and 3 (each within the scatter of the next, the first and the last beyond it).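

The replacement of fluoro by methoxy on this aromatic carbon has no single effect in this assay: on the core of compound 3 it gives a 1.6-fold lower number from compound 3 to compound 4 (0.20 log units; within the scatter), so the rise seen on the core of compound 1 does not carry over. The size of the step differs with the core: the same change on two cores in this assay, a 4.6-fold higher number (0.67 log units; beyond the scatter) from compound 1 to compound 2 and a 1.6-fold lower number (0.20 log units; within the scatter) from compound 3 to compound 4, 7.3-fold (0.87 log units) apart, beyond the scatter of two such steps

Among these compounds, with only two pairs, it remains open which of these two outcomes is the more usual one. Also open, going by these compounds, is how an amine or a longer chain such as ethoxy on the same aromatic carbon would read in this assay.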